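A few compounds are considered here, and "the series" means these few. Any claim that something is new, unique, unknown or untested is made for them only; others in the source may bear on it.

Measured so far in an ADME assay on RAW264.7 cells (Mus musculus) for cytotoxicity, read by MTT assay, with a stated time of 18 h; a higher number here means that more compound is tolerated, a lower number that less compound is tolerated:
compound 1 `C=C1C(=O)OC[C@H]1CCOC(=O)Nc1ccc(I)cc1`, 12800 nM
compound 2 `C=C1C(=O)OC[C@@H]1CCOC(=O)Nc1ccc(I)cc1`, 12500 nM
compound 3 `C=C1C(=O)OC[C@H]1CCOC(=O)Nc1cc(C(F)(F)F)cc(C(F)(F)F)c1`, 13900 nM

Compound 1 stands second highest of the three numbers; compound 2 lies nearest and compound 3 furthest, and both gaps are within the scatter. Going by the values given here, the only step between compounds differing in one place is a 1.0-fold lower number from compound 1 to compound 2 (0.01 log units; within the scatter), and it rests on (the fact that compounds 1 and 2 differ only in the configuration as drawn).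

Compound 4 `C=C1C(=O)OC[C@H]1CCOC(=O)Nc1ccc(CCCC)cc1` differs from compound 1 by butyl in place of iodo on an aromatic carbon. Among the compounds with values here, no measured step touches the group on the aromatic ring, so none bears directly on this change; the one step measured was within the scatter, and the three numbers sit close together. For compound 4 in this assay a step within the scatter is therefore expected, a 1.0-fold higher number from compound 1 to compound 4 (0.01 log units; within the scatter). The estimate for compound 4 is 13000 nM, with a range from 6000 nM to 28000 nM.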

Compound 4, half-maximal cytotoxic concentration: 15900 nM
For compound 4 the middle estimate is 1.2-fold (0.09 log units) below the measured one; the measured number falls inside the stated range.
By their numbers in this assay, from the lowest: compounds 2, 1, 3 and 4 (each within the scatter of the next).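

In this assay, going by these compounds alone, butyl in place of iodo on an aromatic carbon gives a 1.2-fold higher number from compound 1 to compound 4 (0.09 log units; within the scatter) and so is the first single change read at this position, para to a large group. Across this one pair, the exchange of a halogen for an alkyl chain leaves the number within the scatter. Nothing measured bears on why the number holds across this change.

Still open, as far as these compounds go, is whether an amine or a carboxylic acid at this position would give a step beyond the scatter. From the compounds shown here alone, a longer chain in place of butyl is equally open.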